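Nitro in Place of Methoxy: Expected Effect on Cytotoxicity

This account rests on a few compounds, and the source may have more. Where it says the series, first, only, none or still open, it means among the compounds named here.

Of the compounds shown here, two sharing one core have been measured. Compound 1 `O=C1CSC(c2ccc([N+](=O)[O-])cc2)N1CCN1CCCCC1` bears a nitro group; in an ADME assay on Vero cells (Chlorocebus sabaeus) for cytotoxicity, read by neutral red uptake, tested at 25 ug/mL (on this read-out higher numbers stand for a weaker effect at the one concentration tested and lower numbers for a stronger effect), compound 1 gives 100%, which on this read-out means no measurable effect at the one concentration tested. Compound 2 `COc1ccccc1C1SCC(=O)N1CCN1CCCCC1` bears a methoxy group instead; in this assay compound 2 gives 100%, level with compound 1 at the digits shown, the two lying within the scatter of each other. Compound 3 `O=C1CSC(c2ccccc2[N+](=O)[O-])N1CCN1CCCCC1` has not been measured; it differs from compound 2 by nitro in place of methoxy on an aromatic carbon. Within the data shown here, no step between measured compounds is known here; the expectation rests on compound 1, which also bears a nitro group and gives 100% in this assay. The step expected is a number 2 percentage points lower from compound 2 to compound 3 (within the scatter), nothing beyond the scatter. Compound 3 is therefore estimated at 98%, with a range from 85% to 100%.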

Compound 3, a percentage reported as activity, at one concentration (the size of the read-out at that concentration, not a potency): 100%
Compound 3: the middle estimate sits 2 percentage points below what was measured; the measured number falls inside the stated range.
By their numbers in this assay, from the lowest: compounds 1, 2 and 3 (each within the scatter of the next).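

In this assay, among these compounds, nitro in place of methoxy on an aromatic carbon, ortho to a large group, gives no change at the digits printed from compound 2 to compound 3 (within the scatter) and so provides the first direct comparison of these two groups at this position. At the one concentration tested, this exchange leaves the read-out where it was, so neither group stands out here from the other. Nothing available explains this result or shows whether the two groups would still match under other conditions.

As far as these compounds go, whether an amine, a carboxylic acid or a longer chain on this same aromatic carbon would also leave the read-out unchanged remains open. A single concentration also cannot show whether compound 2 and compound 3 would stay level at higher concentrations.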